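Trifluoromethyl for chlorophenyl on the amide aryl ring

The source may hold more compounds than are shown below. What is called first, only, known or untested is meant among the compounds shown, and "the series" means these compounds.

Three compounds of one series have been characterised in an assay on isolated protein for displacement of a labelled ligand from melanin-concentrating hormone receptor 1 (Homo sapiens); a lower number here means a stronger inhibitor, a higher number a weaker inhibitor. Compound 1 `CCCc1cc(N)c2cc(NC(=O)c3ccc(-c4ccc(Cl)cc4)cc3)ccc2n1` gives 0.7 nM and stands at the lowest number of the three. Compound 3 `CCCc1cc(N)c2cc(NC(=O)/C=C/c3ccc(C(C)(C)C)cc3)ccc2n1` gives 22 nM in this assay, and compound 2 `CCCc1cc(N)c2cc(NC(=O)/C=C/c3cccc(Cl)c3)ccc2n1` gives 1100 nM; both steps from compound 1 lie beyond the scatter, so compound 1 is the strongest inhibitor among the measured set. For the measured compounds named here, compounds 2 and 3 carry a different linker from compound 1, and no single-point step between any pair of measured compounds is available.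

Compound 4 `CCCc1cc(N)c2cc(NC(=O)c3ccc(C(F)(F)F)cc3)ccc2n1` has not been measured. It differs from compound 1 in one place: trifluoromethyl in place of 4-chlorophenyl on an aromatic carbon. The aromatic carbon para to a large group now carries a trifluoromethyl where compound 1 carried a 4-chlorophenyl.

Going by the values given here, no measured pair isolates this change. Among the compounds with values here, the only guide is that compound 3, with a tert-butyl in the same region of the distal ring, reaches 22 nM in this assay, whereas compound 1 with its 4-chlorophenyl reaches 0.7 nM. The step from compound 1 to compound 4 is therefore expected to be a loss, a 21-fold higher number from compound 1 to compound 4 (1.33 log units; beyond the scatter), beyond the scatter. Compound 4 is estimated at 15 nM in this assay, with a range from 3 nM to 80 nM.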

Compound 4, half-maximal inhibitory concentration: 10000 nM
Beside the measured number, compound 4's estimate is 670-fold (2.82 log units) below it; measured number above the stated range.
By their numbers in this assay, from the lowest: compound 1; then compound 3; then compound 2; then compound 4.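

In this assay, for the compounds shown here, trifluoromethyl in place of 4-chlorophenyl on an aromatic carbon gives the first single-point step, a 14000-fold higher number from compound 1 to compound 4 (4.15 log units; beyond the scatter), and it is a large one. At this place, para to a large group, the number therefore depends steeply on what the aromatic carbon carries, and with the amide and the shared core unchanged, trifluoromethyl does not stand in for 4-chlorophenyl. No measurement on hand accounts for the size of this step.

The change removes a six-membered aromatic ring and its chlorine together, so this pair cannot show which of them carries the difference; a plain phenyl or a 4-fluorophenyl at the same place would begin to separate the two. Also open, from the compounds shown here alone, is whether the distal ring must be aromatic at all, which a cyclohexyl or a piperidine there would test, and whether a chain such as n-butyl could recover any of the strength of compound 1.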